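Methyl on the saturated ring and cytotoxicity

This account rests on a few compounds, and the source may have more. Where it says the series, first, only, none or still open, it means among the compounds named here.

Compound 1 `Cc1ccc(O)c(C(=O)NCCCCN2CCC[C@@H]3CCCC[C@@H]32)c1` and compound 2 `Cc1ccc(O)c(C(=O)NCCCN2CCC[C@@H]3CCCC[C@@H]32)c1` share an amide-linked phenol; the difference between their two cores is not broken down here. Compound 3 `Cc1ccc(O)c(C(=O)NCCCCN2C(C)CC[C@@H]3CCCC[C@@H]32)c1` carries, relative to compound 1, (methyl in place of hydrogen on a saturated ring carbon). Compound 4 `Cc1ccc(O)c(C(=O)NCCCN2CCC(C)[C@@H]3CCCC[C@@H]32)c1` stands to compound 2 in the same kind of change, (methyl in place of hydrogen on a saturated ring carbon), but the place is not the same: in compound 3 the methyl sits next to the ring nitrogen and next to the ring atom that bears a large group, whereas in compound 4 it sits next to the ring atom that bears a fused ring and three ring bonds from the ring nitrogen.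

In a functional assay on MDBK cells (Bos taurus) for cytotoxicity (on this read-out lower numbers stand for higher toxicity in this test and higher numbers for lower toxicity in this test), compound 1 gives 30 ug/mL and compound 3 gives 90 ug/mL, a step of a 3.0-fold higher number from compound 1 to compound 3 (0.48 log units; beyond the scatter). For compound 2 in this assay only a limit is known, > 100 ug/mL. One of the three values here sits at the limit of > 100 ug/mL in this assay, at which 1 of the 3 values shown sits.

From compound 2 to compound 4 a step that the limit leaves unreadable from compound 2 to compound 4 is expected in this assay. That expectation rests on a 3.0-fold higher number from compound 1 to compound 3 (0.48 log units; beyond the scatter), with the caution that the place of the methyl differs. Compound 4 is therefore estimated at 180 ug/mL in this assay, expected to lie between 80 ug/mL and 400 ug/mL, and quite possibly again only a limit.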

Compound 4, half-maximal cytotoxic concentration: 100 ug/mL
Compound 4: middle estimate off by 1.8-fold (0.26 log units), on the high side; the measured number falls inside the stated range.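

Compound 2 is known in this assay only as a limit, > 100 ug/mL. Methyl in place of hydrogen on a saturated ring carbon gives a number no higher from compound 2 to compound 4 (the limit leaves the size open), so the rise seen on the core of compound 1 does not carry over as a fixed step to the core of compound 2: the same change on two cores in this assay, a 3.0-fold higher number (0.48 log units; beyond the scatter) from compound 1 to compound 3 and a number no higher (the limit leaves the size open) from compound 2 to compound 4, at least 3.0-fold (0.47 log units) apart, beyond the scatter of two such steps. This does not show whether the core or the place of the methyl accounts for the gap, since the two cores differ and the methyl sits at a different ring carbon in each pair, and the limit also leaves the true size of the second step open.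

The compounds shown leave open what each methyl would do at the other's place, on the other core, which is the pairing that would separate place from core. They also leave open whether an ethyl or a hydroxyl group at either ring carbon would follow the methyl in this read-out.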